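From Methyl to Isopropyl on the Aromatic Carbon

The source may report more compounds than this note shows. Statements on the series, on what has been measured and on what is new or still open speak of the compounds shown alone.

Compound 3 `Cc1ccc(CCCN2CC=C(CCC(=O)NO)C2=O)cc1` is one of three compounds that share a single core. In a functional assay on PC-3 cells (Homo sapiens) for inhibition, read by sulforhodamine B assay (a higher number here means a weaker inhibitor of growth, a lower number a stronger inhibitor of growth), compound 3 gives 3480 nM. Compound 1 `O=C(CCC1=CCN(CCCc2ccc(Cl)cc2)C1=O)NO` gives 3480 nM and compound 2 `CCOc1ccc(CCCN2CC=C(CCC(=O)NO)C2=O)cc1` gives 3480 nM in this assay, so compound 3 stands level with both. The steps of no change at the digits printed from compound 1 to compound 3 (within the scatter), no change at the digits printed from compound 2 to compound 3 (within the scatter) and no change at the digits printed from compound 1 to compound 2 (within the scatter) all show that swapping the group on the aromatic carbon moved nothing beyond the scatter. Compound 4 `CC(C)c1ccc(CCCN2CC=C(CCC(=O)NO)C2=O)cc1` differs from compound 3 by isopropyl in place of methyl on an aromatic carbon. All three measured steps bear on this change and each was flat. The expected step for compound 4 is therefore no change at the digits printed from compound 3 to compound 4 (within the scatter), none beyond the scatter. Compound 4 is estimated at 3480 nM, between 1700 nM and 7000 nM.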

Compound 4, concentration for 50% growth inhibition: 3480 nM
Compound 4: middle estimate and measured number agree at the digits printed; low and high end bracket the measured number.
By their numbers in this assay, from the lowest: compounds 1, 2, 3 and 4 (each within the scatter of the next).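

In this assay the flat run at this position now extends to isopropyl, with 3 heavy atoms against the 1 of methyl: the steps read no change at the digits printed from compound 3 to compound 4 (within the scatter) and no change at the digits printed from compound 2 to compound 4 (within the scatter) and also no change at the digits printed from compound 1 to compound 4 (within the scatter) in the same direction of comparison. Chloro, ethoxy, methyl and isopropyl, para to a large group, thus all stand level on this aromatic carbon. Nothing available explains why these four groups stand level.

The compounds shown leave open whether an amine or a carboxylic acid on this aromatic carbon would stay level with these four.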